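Benzyl ring variation in a peptidomimetic series

The source may hold more compounds than are shown below. What is called first, only, known or untested is meant among the compounds shown, and "the series" means these compounds.

Compound 1: `Cc1ccc(CNC(=O)C(=O)N[C@@H](C)C(=O)N[C@@H](CC(=O)O)C(=O)COc2c(F)c(F)cc(F)c2F)cc1` gives 50 nM
Compound 2: `C[C@H](NC(=O)C(=O)NCc1ccccc1F)C(=O)N[C@@H](CC(=O)O)C(=O)COc1c(F)c(F)cc(F)c1F` gives 207 nM
Compound 3: `C[C@H](NC(=O)C(=O)NCc1c(Cl)cccc1Cl)C(=O)N[C@@H](CC(=O)O)C(=O)COc1c(F)c(F)cc(F)c1F` gives 110 nM

Of the compounds shown here, three sharing one core have been tested in a functional assay on Jurkat cells (Homo sapiens); on this read-out higher numbers stand for weaker inhibition and lower numbers for stronger inhibition. Compound 1 has the lowest number of the three; compound 3 is nearest, and compound 2 is furthest away. Replacing 4-methylphenyl by 2-fluorophenyl gave a 4.1-fold higher number from compound 1 to compound 2 (0.62 log units; beyond the scatter), and replacing it by 2,6-dichlorophenyl gave a 2.2-fold higher number from compound 1 to compound 3 (0.34 log units; beyond the scatter). Between those two halogenated rings the change was a 1.9-fold lower number from compound 2 to compound 3 (0.27 log units; within the scatter).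

The unmeasured compound 4 is `C[C@H](NC(=O)C(=O)NCc1cc(F)cc(F)c1)C(=O)N[C@@H](CC(=O)O)C(=O)COc1c(F)c(F)cc(F)c1F`. It differs from compound 1 in a single place: 3,5-difluorophenyl in place of 4-methylphenyl on a saturated chain carbon bound to an amide-type nitrogen. Both measured departures from 4-methylphenyl at this position raised the number in this assay by a modest amount, and a ring bearing fluorine is again what enters. The step is therefore expected to be upward and modest, in line with compound 3 rather than compound 2, though the two measured halogenated rings leave the size uncertain. For compound 4 the expected step is a 2.4-fold higher number from compound 1 to compound 4 (0.38 log units; beyond the scatter), giving an estimated value of 120 nM with a likely range from 50 nM to 300 nM.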

Compound 4, half-maximal inhibitory concentration: 16 nM
Beside the measured number, compound 4's estimate is 7.5-fold (0.88 log units) above it; measured number below the stated range.
By their numbers in this assay, from the lowest: compound 4; then compound 1; then compounds 3 and 2 (each within the scatter of the next).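

Among the earlier compounds, every ring tried at this place gave a higher number than the 4-methylphenyl of compound 1, but in this assay the 3,5-difluorophenyl ring shows a 3.1-fold lower number from compound 1 to compound 4 (0.49 log units; beyond the scatter) and so shows that a change here can also strengthen inhibition. Halogen-bearing rings also turn out to differ widely: replacing 2,6-dichlorophenyl gives a 6.9-fold lower number from compound 3 to compound 4 (0.84 log units; beyond the scatter) and replacing 2-fluorophenyl gives a 13-fold lower number from compound 2 to compound 4 (1.11 log units; beyond the scatter) (the only step of this set printed as large), so compound 2 and compound 3 go against any simple rule that a halogen on this ring strengthens inhibition, just as compound 4 goes against the rule that it weakens it. Nothing in the data available here accounts for these differences.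

On these data alone, it remains open whether both fluorines are needed, which a 3-fluorophenyl ring would test, and whether other groups with the same substitution pattern, such as 3,5-dichlorophenyl or 3,5-dimethylphenyl, would behave like compound 4. Also open, as far as these compounds go, is whether a longer chain carrying the same ring, such as 2-(3,5-difluorophenyl)ethyl in place of 3,5-difluorobenzyl, would keep this stronger inhibition.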